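This account rests on a few compounds, and the source may have more. Where it says the series, first, only, none or still open, it means among the compounds named here.

Compound 1 `Nc1cc(N)c2nc(-c3ccccc3)c(Oc3ccc(Cl)c(Cl)c3)nc2c1`: < 100000 nM
Compound 2 `COc1cc(CNc2nc3cc(N)cc(N)c3nc2-c2ccccc2)cc(OC)c1OC`: 34700 nM

In a functional assay on M14 cells (Homo sapiens) for inhibition, read by sulforhodamine B assay, with a stated time of 48 h (a higher number here means that more compound is tolerated, a lower number that less compound is tolerated), compound 1 gives < 100000 nM, which is a limit of the assay and not a number, as noted in the limit of < 100000 nM in this assay, at which 1 of the 2 values shown sits. Compound 2 gives 34700 nM in this assay. Compound 3 `COc1ccc(Sc2nc3cc(N)cc(N)c3nc2-c2ccccc2)cc1` carries (4-methoxyphenyl)sulfanyl in place of 3,4-dichlorophenoxy on an aromatic carbon. Nothing measured bears on this change. Compound 3 is expected to sit near the value seen for compound 2, at 30000 nM with a range of 10000 nM to 100000 nM. The expected step that the limit leaves unreadable from compound 1 to compound 3 in this assay is small and judged not beyond the scatter.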

Compound 3, concentration lethal to 50% of the cells: < 100000 nM
Compound 3: only a limit was reported (the forecaster's own chance of this, stated with the estimate: 30%); the middle value is on the limit's open side.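

No step can be read from compound 1 to compound 3, because both results are limits of the assay and not numbers: the limit of < 100000 nM in this assay, at which 2 of the 3 values shown sit. In this assay the compounds shown leave open how (4-methoxyphenyl)sulfanyl compares with 3,4-dichlorophenoxy.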